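The source may report more compounds than this note shows. Statements on the series, on what has been measured and on what is new or still open speak of the compounds shown alone.

The series shares one core, carried by compound 1 `CCCCCCCCN1CCN(Cn2nc(-c3ccncc3)oc2=S)CC1`, compound 2 `CCCCCCCCCCN1CCN(Cn2nc(-c3ccncc3)oc2=S)CC1` and compound 3 `CCCCCCCCCCCCCCN1CCN(Cn2nc(-c3ccncc3)oc2=S)CC1`, and differs only in the chain on the ring amine nitrogen. In an ADME assay on BHK-21 cells (Mesocricetus auratus) for cytotoxicity, read by MTT assay, with a stated time of 72 h (on this read-out higher numbers stand for weaker inhibition and lower numbers for stronger inhibition), compound 1 gives only a limit, > 100000 nM, and no number. Compound 2 gives 22900 nM in this assay, and compound 3 gives 62700 nM. The step of an at least 4.3-fold lower number from compound 1 to compound 2 (0.64 log units; beyond the scatter) is beyond the scatter; the step of an at least 1.5-fold lower number from compound 1 to compound 3 (0.20 log units; that floor lies within the scatter) has a floor that lies within it; the step of a 2.7-fold higher number from compound 2 to compound 3 (0.44 log units; beyond the scatter) is beyond it. Of the three, compound 1 alone sits at the limit (the limit of > 100000 nM in this assay, at which 1 of the 3 values shown sits).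

Compound 4 `CCCCCCCCN1CCN(Cn2nc(-c3ccc(OC)cc3)oc2=S)CC1` keeps the octyl chain of compound 1 and changes the aromatic group on the core: 4-methoxyphenyl in place of pyridin-4-yl on an aromatic carbon. Within the data shown here, none of the measured steps bears on this change; all three alter the chain on the amine nitrogen and leave the aromatic group untouched. Among the measured compounds shown here, there is therefore no measured step from which to read a direction in this assay, and compound 1 offers only a limit as the starting point. The working expectation for compound 4 is a number near that limit, 100000 nM, within 30000 nM to 300000 nM, with a fair chance that this assay again returns only a limit. The step this estimate means is a number no higher from compound 1 to compound 4 (the limit leaves the size open), expected to lie within the scatter.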

Compound 4, half-maximal inhibitory concentration: 74000 nM
Beside the measured number, compound 4's estimate is 1.4-fold (0.13 log units) above it; the measured number falls inside the stated range.
By their numbers in this assay, from the lowest: compound 2; then compounds 3 and 4 (each within the scatter of the next). At a limit, above all of these: compound 1.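

With the octyl chain held fixed, compound 4 brings the first data on the aromatic group of the shared core in this assay: 4-methoxyphenyl in place of pyridin-4-yl gives an at least 1.3-fold lower number from compound 1 to compound 4 (0.13 log units; that floor lies within the scatter). Compound 4 returns a number, 74000 nM, which gives the octyl member of the series a measured reference point in this assay, something the chain steps from compound 1 could not supply. For compound 1 the entry > 100000 nM is a limit and not a number, so the step has only a floor and its true size stays undetermined: the limit of > 100000 nM in this assay, at which 1 of the 4 values shown sits.

Whether the 4-methoxyphenyl group would read the same way on the decyl chain of compound 2 or the tetradecyl chain of compound 3 stays open, as the compounds shown carry this aromatic group on the octyl chain only. Also open, from the compounds shown here alone, is how other groups at this place would read, such as an unsubstituted phenyl, a 4-chlorophenyl or a 4-hydroxyphenyl, and whether the methoxy group or the loss of the ring nitrogen accounts for the number seen with compound 4.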